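A few compounds are considered here, and "the series" means these few. Any claim that something is new, unique, unknown or untested is made for them only; others in the source may bear on it.

Three compounds share one core and differ only in the group on the amide nitrogen. Compound 1 `COc1cc2c(cc1OC)C(CC(=O)N(C)C)CC2`, compound 2 `COc1cc2c(cc1OC)C(CC(=O)NC(C)C)CC2` and compound 3 `CCCCNC(=O)CC1CCc2cc(OC)c(OC)cc21` were tested in a functional assay on the whole organism (strain Swiss albino) for inhibition, with Mus musculus as the target, in the writhing test, with stated times of 60 min and 15 min, at a dose of 100 mg/kg by the oral route; on this read-out higher numbers stand for more inhibition at the one dose given (going by the name of the read-out) and lower numbers for less inhibition; compound 1 gives 22.6%, compound 2 gives 29.3% and compound 3 gives 39.4%, the highest of the three. The steps of a number 16.8 percentage points higher from compound 1 to compound 3 (beyond the scatter) and a number 10.1 percentage points higher from compound 2 to compound 3 (beyond the scatter) both point upward, while a number 6.7 percentage points higher from compound 1 to compound 2 (within the scatter) stays inside the scatter. Compound 4 `COc1cc2c(cc1OC)C(CC(=O)NC1CCCCC1)CC2` differs from compound 3 by cyclohexyl in place of butyl on an amide-type nitrogen. The two upward steps toward the butyl group suggest that a further rise of modest size, or none beyond the scatter, is expected for compound 4, a number 5.6 percentage points higher from compound 3 to compound 4 (within the scatter). Compound 4 is therefore estimated at 45%, within 30% to 60%.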

Compound 4, a percentage reported as inhibition, in the whole organism at one dose (the size of the read-out at that dose, not a potency): 44.7%
Beside the measured number, compound 4's estimate is 0.3 percentage points above it, within the range that was stated.
By their numbers in this assay, from the lowest: compounds 1 and 2 (each within the scatter of the next); then compounds 3 and 4 (each within the scatter of the next).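

Among these compounds only compound 4 carries a ring on the amide nitrogen, and cyclohexyl in place of butyl gives a number 5.3 percentage points higher from compound 3 to compound 4 (within the scatter) so ring and open chain cannot be told apart here. Against the other two groups, cyclohexyl gives a number 15.4 percentage points higher from compound 2 to compound 4 (beyond the scatter) and a number 22.1 percentage points higher from compound 1 to compound 4 (beyond the scatter) so this position takes a ring and keeps the level reached with butyl. No evidence is available to explain these differences.

Going by these compounds, whether a phenyl ring, a piperidine ring or a longer chain such as hexyl on this nitrogen would go beyond compound 3 and compound 4 stays open.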